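Swapping Isobutyl for Cyclohexyl on an Amine Nitrogen

This account rests on a few compounds, and the source may have more. Where it says the series, first, only, none or still open, it means among the compounds named here.

Within the data shown here, in a functional assay on HT-29 cells (Homo sapiens) for inhibition, read by sulforhodamine B assay, with a stated time of 72 h (on this read-out higher numbers stand for weaker inhibition and lower numbers for stronger inhibition), compound 1 (`CC(C)CNC(=C\C(=O)/C=C/c1ccc(O)cc1)/C=C/c1ccc(O)cc1`) gives 22500 nM and is the only compound here with an actual number. Compound 2 (`COc1cc(/C=C/C(=O)/C=C(/C=C/c2ccc(OC(C)=O)c(OC)c2)NCC(C)C)ccc1OC(C)=O`) reads > 25000 nM as a limit of the assay and not a number. Compound 3 (`COc1cc(/C=C/C(=O)CC(=O)/C=C/c2ccc(OC(C)=O)c(OC)c2)ccc1OC(C)=O`) also reads > 25000 nM as a limit of the assay. Among the measured compounds shown here, compound 1 therefore has no measured neighbour, and no step between measured compounds is available as a guide.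

Compound 4 (`O=C(/C=C(/C=C/c1ccc(O)cc1)NC1CCCCC1)/C=C/c1ccc(O)cc1`) differs from compound 1 in one place, with cyclohexyl in place of isobutyl on an amine nitrogen. The rest of the molecule stays the same. For the measured compounds named here, with no measured step to draw on, in this assay no shift beyond the usual scatter is expected in either direction. The expected step is a 1.3-fold lower number from compound 1 to compound 4 (0.12 log units; within the scatter) and it should stay small. For compound 4 the estimated value is 17000 nM with an expected range from 7000 nM to 25000 nM in this measurement.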

Compound 4, half-maximal inhibitory concentration: 5900 nM
The estimate for compound 4 lay 2.9-fold (0.46 log units) above the measured number; measured number outside the range, below it.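

Cyclohexyl in place of isobutyl on an amine nitrogen brings a 3.8-fold lower number from compound 1 to compound 4 (0.58 log units; beyond the scatter) in this assay, the first measured step in this set. The position is therefore not indifferent to what it carries, even though neither group has a hydrogen-bond donor, a hydrogen-bond acceptor or a net charge. This is a single pair, so it shows the direction of this one change on the core of compound 1 and sets no rule for the position.

The compounds shown cannot separate the effect of having a ring from that of having a larger group, a question that a straight hexyl chain or a benzyl group on the same nitrogen would address. Compound 2 and compound 3 add no number to this comparison, as their readings are limits of the assay: the limit of > 25000 nM in this assay, at which 2 of the 4 values shown sit.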